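The source may hold more compounds than are shown below. What is called first, only, known or untested is meant among the compounds shown, and "the series" means these compounds.

In an ADME assay on H9c2 cells (Rattus norvegicus) for cytotoxicity, read by resazurin assay, with a stated time of 72 h (on this read-out lower numbers stand for higher toxicity in this test and higher numbers for lower toxicity in this test), compound 1 `C/C(=N\N=c1\scc(-c2ccccc2)n1C)c1ccc(Cl)c(Cl)c1` gives > 50000 nM, which is a limit of the assay and not a number. Compound 2 `C/C(=N\N=c1\scc(-c2ccccc2)n1-c1ccccc1)c1ccc(Cl)c(Cl)c1` gives > 50000 nM, again a limit. Going by the values given here, compound 3 `C/C(=N\Nc1nc(-c2ccccn2)cs1)c1ccc(Cl)c(Cl)c1` gives 10200 nM, the only true number among the three.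

The next compound, compound 4 `C/C(=N\Nc1nc(-c2ccc(Cl)c(Cl)c2)cs1)c1ccc(Cl)c(Cl)c1`, differs from compound 3 at one place: 3,4-dichlorophenyl in place of pyridin-2-yl on an aromatic carbon. In words, 3,4-dichlorophenyl stands in place of pyridin-2-yl on an aromatic carbon.

The measured data offer little guidance on the size of this change. Among the compounds with values here, the single measured step, a step that the two limits leave unreadable from compound 1 to compound 2, concerns a group on an aromatic nitrogen and gives no size to carry over. Within the data shown here, the only other guide is weak: compound 3 alone carries pyridin-2-yl, while compounds 1 and 2 lack it and sit at the limit of > 50000 nM in this assay, at which 2 of the 3 values shown sit. However, those two compounds also differ from compound 3 elsewhere, so this rests on three compounds only.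

A modest move towards a higher number in this assay is therefore expected, with low confidence. The expected change is a 2.0-fold higher number from compound 3 to compound 4 (0.29 log units; within the scatter). For compound 4 the estimate is 20000 nM, with an expected range of 6000 nM to 50000 nM.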

Compound 4, half-maximal cytotoxic concentration: > 50000 nM
Compound 4 ended at the assay's limit (the forecaster's own chance of this, stated with the estimate: 35%); middle value at least 2.5-fold (0.39 log units) from the limit.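

At this position, an aromatic carbon of the five-membered aromatic ring with 1 nitrogen and 1 sulfur, next to the ring nitrogen, the group at this site clearly affects the read-out in this assay. Placing 3,4-dichlorophenyl there instead of pyridin-2-yl gives an at least 4.9-fold higher number from compound 3 to compound 4 (0.69 log units; beyond the scatter), the first step in this set with a readable size, and that size is only a lower bound. Of the four compounds, compound 3 with its pyridin-2-yl group is now the only one with a true number, though compounds 1 and 2 also differ from it elsewhere, and the other compounds stand together at one limit: the limit of > 50000 nM in this assay, at which 3 of the 4 values shown sit.

The compounds shown leave open the full size of this step, and whether it follows from the loss of the ring nitrogen of pyridin-2-yl or from the entry of the two chlorine atoms. A plain phenyl or a 4-chlorophenyl at this position on the core of compound 3 would separate these two parts of the change, and an aminophenyl group would test whether the lower toxicity in this test extends beyond chlorine-bearing rings.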